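This account rests on a few compounds, and the source may have more. Where it says the series, first, only, none or still open, it means among the compounds named here.

Measured compounds in a functional assay on the whole organism with Rattus norvegicus as the target; on this read-out higher numbers stand for an effect only at larger amounts of compound and lower numbers for an effect already at smaller amounts:
Compound 1 `N#CCn1c(=N)sc2cc(OC(F)(F)F)ccc21` — compound 1 gives 3.5 mg/kg.
Compound 2 `CN(C)S(=O)(=O)CCn1c(=N)sc2cc(OC(F)(F)F)ccc21` — compound 2 gives only a limit of this assay, > 10 mg/kg.
Compound 3 `C[S+]([O-])Cn1c(=N)sc2cc(OC(F)(F)F)ccc21` — compound 3 gives 2.3 mg/kg.

Compound 2 stands at the edge of the numbers shown: the limit of > 10 mg/kg in this assay, at which 1 of the 3 values shown sits, so for compound 2 there is no measured value, only the limit. Compound 4 `N=c1sc2cc(OC(F)(F)F)ccc2n1CC[S+]([O-])c1ccccc1` differs from compound 2 in one place: a group of 8 heavy atoms (6 carbon, 1 oxygen, 1 sulfur; one six-membered aromatic ring of carbon only) in place of a group of 6 heavy atoms (2 carbon, 1 nitrogen, 2 oxygen, 1 sulfur; no ring), on a saturated chain carbon, two bonds along the chain from an aromatic nitrogen. Going by the values given here, two measured steps bear on this. The step of an at least 2.8-fold higher number from compound 1 to compound 2 (0.45 log units; beyond the scatter) shows the dimethylsulfamoyl-bearing chain carrying the number up to the limit. The step of an at least 4.3-fold lower number from compound 2 to compound 3 (0.63 log units; beyond the scatter) shows that exchanging that chain for a smaller chain holding sulfur and oxygen brings the number back down. Compound 4 again carries a chain holding sulfur and oxygen, here with an aromatic ring of carbon only and sitting two bonds along the chain from the aromatic nitrogen. A move downward from the limit is therefore expected, an at least 2.0-fold lower number from compound 2 to compound 4 (0.30 log units; that floor lies within the scatter). Among the compounds with values here, no measured compound carries the entering group, so the size of that move is uncertain. Compound 4 is estimated at 5 mg/kg, with a range from 2 mg/kg to 15 mg/kg.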

Compound 4, dose for half-maximal effect: 4.2 mg/kg
Compound 4: middle estimate off by 1.2-fold (0.08 log units), on the high side; low and high end bracket the measured number.
By their numbers in this assay, from the lowest: compounds 3, 1 and 4 (each within the scatter of the next). At a limit, above all of these: compound 2.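

In this assay, placing the group with a six-membered aromatic ring of carbon in place of dimethylsulfamoyl, on a saturated chain carbon, two bonds along the chain from an aromatic nitrogen, gives an at least 2.3-fold lower number from compound 2 to compound 4 (0.37 log units; beyond the scatter), so a group of 8 heavy atoms at this place does not hold the number at the limit. Compound 4, at 4.2 mg/kg, lies within the scatter of compound 1 at 3.5 mg/kg. The step to compound 4 is only a floor, because compound 2 has a limit and no measured number: the limit of > 10 mg/kg in this assay, at which 1 of the 4 values shown sits.

The compounds shown do not separate the contribution of the aromatic ring from that of the sulfur and oxygen in the entering group. On these data alone, how an amine, a carboxylic acid or a longer chain would read at this place remains open.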